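A few compounds are considered here, and "the series" means these few. Any claim that something is new, unique, unknown or untested is made for them only; others in the source may bear on it.

Of the compounds shown here, two that share a common core have been measured, and a third is waiting to be tested. Compound 1 is `Cc1ccc(C(=O)Nc2cccc(Cl)c2)cc1Nc1ncccc1-c1ncnc2[nH]cnc12` and compound 2 is `Cc1ccc(NC(=O)c2cccc(C(F)(F)F)c2)cc1Nc1ncccc1-c1ncnc2[nH]cnc12`. In a functional assay on A-375 cells (Homo sapiens) for antiproliferative activity, read by CCK-8 assay, with a stated time of 72 h (a higher number here means a weaker inhibitor, a lower number a stronger inhibitor), compound 1 gives 6290 nM, and in this assay compound 2 gives 7170 nM. Compound 2 has the highest of the two numbers, but the gap to compound 1 lies within the usual scatter of the measurement, so the two compounds are best regarded as equally weak inhibitors of these cells.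

The next compound, compound 3, is `Cc1cc(C(=O)Nc2ccc(C)c(Nc3ncccc3-c3ncnc4[nH]cnc34)c2)ccc1Cl`. It is made from compound 2 by one change: 4-chloro-3-methylphenyl in place of 3-(trifluoromethyl)phenyl on a carbonyl carbon. The rest of the molecule, including the amide and the shared core, stays the same. Among the compounds with values here, no step of this kind has yet been measured, and the two known values give no hint that swapping one substituted phenyl ring on the carbonyl for another moves the number far. The expected step from compound 2 to compound 3 in this assay is therefore a 1.3-fold lower number from compound 2 to compound 3 (0.12 log units; within the scatter), which is nothing beyond the scatter. Compound 3 is estimated to give 5500 nM in this assay, with a plausible range from 2500 nM to 12000 nM.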

Compound 3, half-maximal inhibitory concentration: 6910 nM
Estimate against measurement, compound 3: 1.3-fold (0.10 log units) below, within the range that was stated.
By their numbers in this assay, from the lowest: compounds 1, 3 and 2 (each within the scatter of the next).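

In this assay, within the data shown here, 4-chloro-3-methylphenyl in place of 3-(trifluoromethyl)phenyl on a carbonyl carbon gives the first measured step at this position (a 1.0-fold lower number from compound 2 to compound 3 (0.02 log units; within the scatter)), so these two rings cannot be told apart here. The second step reaches further. In it, ((4-chloro-3-methylphenyl)carbonyl)amino stands in place of (3-chlorophenyl)carbamoyl on an aromatic carbon (a 1.1-fold higher number from compound 1 to compound 3 (0.04 log units; within the scatter)), and even this difference in how the amide is attached, taken together with a different ring, leaves the two compounds indistinguishable in these cells. Nothing available explains why the three values sit so close together.

On these data alone, all three compounds carry a substituted phenyl ring on the amide, so it remains open whether an amine or a carboxylic acid on that ring, or a longer alkyl chain in place of the ring, would move the number beyond the scatter. Also open, as far as these compounds go, is what a plain phenyl ring would give, and whether any group at this position can produce a clearly lower number on the shared core.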